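Adding a Hydroxy Group to the Side Chain of Compound 2

The source may report more compounds than this note shows. Statements on the series, on what has been measured and on what is new or still open speak of the compounds shown alone.

Of the compounds shown here, two sharing one core have so far been measured in an assay on HeLa cells for inhibition of sphingosine-1-phosphate transporter SPNS2 (Mus musculus), read by LC-MS, tested at 2 uM; on this read-out higher numbers stand for more inhibition at the one concentration tested (going by the name of the read-out) and lower numbers for less inhibition. Compound 1 `CCCCCCCCCCc1ccc(-c2noc([C@H](CCCCN)NC(C)=O)n2)cc1` gives 40%, and compound 2 `CCCCCCCCCCc1ccc(-c2noc(CCCN3CCCC3)n2)cc1` gives 3%. Among the compounds with values here, the single measured step, a number 37 percentage points lower from compound 1 to compound 2 (beyond the scatter), exchanges the whole side chain on the aromatic carbon. On these two numbers compound 2 stands lowest, with compound 1 higher by a step beyond the scatter.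

The unmeasured compound 3 `CCCCCCCCCCc1ccc(-c2noc(CC(O)CN3CCCC3)n2)cc1` differs from compound 2 by hydroxy in place of hydrogen on a saturated chain carbon bound to two saturated chain carbons. Within the data shown here, no measured step bears on this change: the one known step swaps the entire side chain, whereas here the 3-(pyrrolidin-1-yl)propyl chain is kept and only a hydroxy enters on it. The expectation for compound 3 in this assay therefore rests on compound 2 alone. The step of a number 7 percentage points higher from compound 2 to compound 3 (within the scatter) is expected to remain within the scatter, with no clear direction. Compound 3 is estimated at 10%, with a range from 0% to 30%.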

Compound 3, a percentage reported as inhibition, at one concentration (the size of the read-out at that concentration, not a potency): 21%
Beside the measured number, compound 3's estimate is 11 percentage points below it; measured number inside the range.
By their numbers in this assay, from the lowest: compound 2; then compound 3; then compound 1.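

In this assay, the hydroxy is the first change shown that keeps the 3-(pyrrolidin-1-yl)propyl chain in place, and it gives a number 18 percentage points higher from compound 2 to compound 3 (beyond the scatter). This shows that the saturated chain carbon bound to two saturated chain carbons is not a silent position: one added hydroxy moves the read-out by more than the scatter, whereas the earlier comparison could speak only to the exchange of a whole side chain. Even so, the 2-hydroxy-3-(pyrrolidin-1-yl)propyl chain does not reach the level of the 1-acetamido-5-aminopentyl chain, leaving a number 19 percentage points lower from compound 1 to compound 3 (beyond the scatter), and nothing available accounts for either step.

Whether the step belongs to the hydroxy itself stays open, since the compounds shown do not tell how a methoxy, an amine or a fluorine on the same carbon would read. They also leave open whether the hydroxy would count in the same way on a longer chain, and how far the read-out would move at any other concentration.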